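The source may report more compounds than this note shows. Statements on the series, on what has been measured and on what is new or still open speak of the compounds shown alone.

In an ADME assay on HaCaT cells (Homo sapiens) for inhibition, read by sulforhodamine B assay, with a stated time of 48 h (a higher number here means a weaker inhibitor of growth, a lower number a stronger inhibitor of growth), compound 1, with the structure `CC(C)(C)NCc1c(C(=O)O)nn(-c2ccccc2)c1-c1ccc(F)cc1`, gives only a limit of > 680000 nM. Compound 2, `CC(C)(C)NCc1c(C(=O)O)nn(-c2ccccc2)c1-c1ccc(Cl)cc1`, likewise reaches only the limit > 652000 nM in this assay. Compound 3, `CC(C)(C)NCc1c(C(=O)O)nn(-c2ccccc2)c1-c1ccccc1`, stays at the limit > 716000 nM in this assay. The step that the two limits leave unreadable from compound 3 to compound 2 is therefore a change of chloro in place of hydrogen on an aromatic carbon whose size cannot be read. The cores of compound 1 and compound 3 differ by fluoro in place of hydrogen on an aromatic carbon. Compound 4, `CC(C)(C)NCc1c(C(=O)O)nn(-c2ccc(Cl)cc2)c1-c1ccc(F)cc1`, carries the same change as compound 2 does against compound 3, namely (chloro in place of hydrogen on an aromatic carbon). Since no value among the three measured compounds rises above a limit, the step from compound 1 to compound 4 is expected to be a step that the limit leaves unreadable from compound 1 to compound 4 in this assay, that is, essentially no readable step. Compound 4 is accordingly expected to give about 700000 nM, likely somewhere between 250000 nM and 2000000 nM, and most probably only another limit.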

Compound 4, concentration for 50% growth inhibition: 28700 nM
For compound 4 the middle estimate is 24-fold (1.39 log units) above the measured one; the measured number lies below the stated range.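

In this assay, the change from phenyl to 4-chlorophenyl gives an at least 23-fold lower number from compound 1 to compound 4 (1.37 log units; beyond the scatter), so chloro in place of hydrogen on this phenyl group is tied to a large step in the core of compound 1. The same exchange on the other aromatic ring, from compound 3 to compound 2, has no readable size, and compound 2 remains at a limit: the limit of > 652000 nM in this assay, at which 1 of the 4 values shown sits. The series therefore does not show whether the change carries over from one core to another, and a single readable step sets no general rule.

On these data alone, it remains open whether bromo or methyl would do the same as chloro in compound 4. Also open, as far as these compounds go, is whether an amide in place of the carboxylic acid would preserve the lower number.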